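A few compounds are considered here, and "the series" means these few. Any claim that something is new, unique, unknown or untested is made for them only; others in the source may bear on it.

The measured compounds are:
compound 1, `CCCCS(=O)(=O)Oc1ccc(/C=C/C(=O)Nc2ccc(CC)cc2)cc1OC`, 89000 nM;
compound 2, `CCCCOC(=O)/C=C/c1ccc(OS(=O)(=O)c2ccc(Cl)cc2)c(OC)c1`, 14000 nM;
compound 3, `COc1cc(/C=C/C(=O)Nc2cccc(C)c2)ccc1OS(=O)(=O)c1ccc(Cl)cc1`, 73500 nM.

All three were examined in a toxicity assay on L02 cells (Homo sapiens) for cytotoxicity, read by MTT assay, with a stated time of 24 h; on this read-out higher numbers stand for lower toxicity in this test and lower numbers for higher toxicity in this test. Compound 1 gives the highest of the three numbers. Its nearest neighbour is compound 3, whose value lies within the scatter of that of compound 1, so no order between these two can be claimed; compound 2 lies furthest away, beyond the scatter, with the lowest number of the three.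

The step to the unmeasured compound 4, `CCCCS(=O)(=O)Oc1ccc(/C=C/C(=O)OC)cc1OC`, is this: methoxy in place of (4-ethylphenyl)amino on a carbonyl carbon. Going by the values given here, one measured step bears on it, taken in the opposite direction: a 5.3-fold higher number from compound 2 to compound 3 (0.72 log units; beyond the scatter). There the (3-methylphenyl)amino group on the carbonyl carbon went with a higher number than butoxy, beyond the scatter. Compound 4 carries the methoxy side of a comparable exchange, in place of the (4-ethylphenyl)amino group of compound 1. The step of a 4.9-fold lower number from compound 1 to compound 4 (0.69 log units; beyond the scatter) is therefore expected to run toward lower numbers, beyond the scatter, mirroring the measured step in size. On that basis compound 4 is estimated at 18000 nM in this assay, with a range from 7000 nM to 45000 nM.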

Compound 4, half-maximal cytotoxic concentration: 208000 nM
Beside the measured number, compound 4's estimate is 12-fold (1.06 log units) below it; measured number above the stated range.
By their numbers in this assay, from the lowest: compound 2; then compounds 3 and 1 (each within the scatter of the next); then compound 4.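

On the core of compound 1, the exchange at the carbonyl carbon does not bring the number down in this assay: the loss of the (4-ethylphenyl)amino group for methoxy gives a 2.3-fold higher number from compound 1 to compound 4 (0.37 log units; beyond the scatter), a modest rise. The earlier pair pointed the other way, with a 5.3-fold higher number from compound 2 to compound 3 (0.72 log units; beyond the scatter) as a (3-methylphenyl)amino group took the place of butoxy, so a phenylamino-type group on this carbonyl carbon does not go with a higher number in every setting shown. The two pairs differ in more than this one group, and nothing measured here accounts for their opposite directions.

Going by these compounds, whether the direction follows the group on the sulfonyl or the alkoxy group itself remains open: a butoxy group on the core of compound 1, or a methoxy group on the core of compound 3, would separate the two. The compounds shown also leave open how a carboxylic acid or a plain primary amide on this carbonyl carbon would read in this assay.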